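Varying the amine group on the ring nitrogen

The source may report more compounds than this note shows. Statements on the series, on what has been measured and on what is new or still open speak of the compounds shown alone.

Of the compounds shown here, two have been measured in a functional assay on Umbilical vein for antagonist activity at B1 bradykinin receptor (Homo sapiens), using Schild analysis, with a stated time of 30 min; on this read-out lower numbers stand for lower potency and higher numbers for higher potency (the scale is a negative logarithm). Compound 1 `CCN(CC)CCN1CCN(C(=O)COCCN(C)S(=O)(=O)c2c(C)cc(OC)cc2C)CC1` gives 7.8. Among the measured compounds shown here, compound 2 `COc1cc(C)c(S(=O)(=O)N(C)CCOCC(=O)N2CCN(CC3CCN(C)CC3)CC2)c(C)c1` gives 8.6, the higher of the two numbers; the single step so far, a number 0.80 log units higher from compound 1 to compound 2 (beyond the scatter), comes from a change at the same ring nitrogen. Compound 3 `COc1cc(C)c(S(=O)(=O)N(C)CCOCC(=O)N2CCN([C@H]3CN4CCC3CC4)CC2)c(C)c1` is not yet measured. Against compound 2 it shows (a group of 8 heavy atoms (7 carbon, 1 nitrogen; 2 six-membered non-aromatic rings with 1 hetero atom each) in place of a group of 8 heavy atoms (7 carbon, 1 nitrogen; one six-membered non-aromatic ring with 1 hetero atom), on an amine nitrogen in a ring). For the measured compounds named here, the one measured step bears on the same place, yet it exchanged (diethylamino)methyl for 1-methylpiperidin-4-yl, whereas here one ring amine gives way to another. Going by the values given here, no measured step of this kind exists, so in this assay no change beyond the scatter is expected, with a wide range to cover the uncertainty. Compound 3 is therefore expected at 8.5, range 7.9 to 9.1. This corresponds to an expected step of a number 0.10 log units lower from compound 2 to compound 3 (within the scatter).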

Compound 3, negative logarithm of the antagonist equilibrium constant: 7.2
Compound 3: middle estimate off by 1.30 log units, on the high side, outside the stated range (below it).
By their numbers in this assay, from the lowest: compound 3; then compound 1; then compound 2.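

In this assay, the amine group on the ring nitrogen proves sensitive to more than its heavy-atom count: (1-methylpiperidin-4-yl)methyl and the group with 2 six-membered non-aromatic rings have the same count, yet the exchange gives a number 1.40 log units lower from compound 2 to compound 3 (beyond the scatter). The open-chain group also compares favourably with the two-ring group, with a number 0.60 log units lower from compound 1 to compound 3 (beyond the scatter), so a ring amine does not by itself give the higher number: compound 2 exceeds compound 1, whereas compound 3 falls short of it. Nothing available explains this loss.

On these data alone, it remains open whether the loss belongs to the two-ring group itself or to its one defined stereocentre. As far as these compounds go, it is also open how a 1-methylpiperidin-4-yl group bound directly to the ring nitrogen, or a simple dimethylamino-bearing chain, would compare.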